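The source may report more compounds than this note shows. Statements on the series, on what has been measured and on what is new or still open speak of the compounds shown alone.

Compound 2 `COc1ccc2nc(C)cc(OCC(=O)Nc3ccc(C)cc3)c2c1` carries the shared core of compound 1 `COc1ccc2nc(C)cc(OCC(=O)Nc3ccccc3)c2c1` with a methyl on the aromatic ring of the anilide. In an ADME assay on HepG2 cells (Homo sapiens) for cytotoxicity, read by trypan blue exclusion, with a stated time of 48 h, in the presence of a further agent that is not named here (on this read-out higher numbers stand for lower toxicity in this test and lower numbers for higher toxicity in this test), compound 1 reaches only a limit, > 155000 nM. In this assay compound 2 likewise reaches only a limit, > 149000 nM. Going by the values given here, the one measured step, a step that the two limits leave unreadable from compound 1 to compound 2, is not readable in size because compound 1 sits at the limit of > 155000 nM in this assay, at which 1 of the 2 values shown sits, and compound 2 sits at the limit of > 149000 nM in this assay, at which 1 of the 2 values shown sits. Compound 2 thus stands at a limit with one further limit beside it, and no number in the series is set.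

Compound 3 `COc1ccc2nc(C)cc(OCC(=O)Nc3ccc(-c4ccccc4)cc3)c2c1` differs from compound 2 by phenyl in place of methyl on an aromatic carbon. Among the compounds with values here, the only step that bears on it is the one from compound 1 to compound 2, which introduces a smaller group and is unreadable in size. Within the data shown here, no measured step therefore gives a direction, and no change beyond the scatter is expected in this assay; the likeliest outcome is a further limit. Compound 3 is estimated at 150000 nM in this assay, within 30000 nM to 300000 nM. The estimated step is a step that the limit leaves unreadable from compound 2 to compound 3.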

Compound 3, half-maximal cytotoxic concentration: > 126000 nM
Compound 3 ended at the assay's limit; the forecaster's own chance of this, stated with the estimate: 75%; the middle value lies beyond the limit too.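

In this assay compound 3 gives > 126000 nM, which is a limit of the assay. Compound 1 and compound 2 also stand at limits, so the steps among these three compounds cannot be read. The compounds shown leave open whether any group on the aromatic ring of the anilide yields a number rather than a limit in this assay.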